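A Sulfonamide Added to a Core That Shows No Toxicity

The compounds below may be only part of what the source reports. "The series", "measured", "known", "first", "only" and "open" are said of these compounds alone.

Compound 1 `COc1ccc([C@H]2CC(=O)N(c3ccccc3)C2)cc1OC1CCCC1` is tested in a functional assay on HEK293 cells (Homo sapiens) for cytotoxicity; a higher number here means that more compound is tolerated, a lower number that less compound is tolerated. In that assay compound 1 gives > 10000 nM, which is a limit of the assay rather than a number. Compound 2 `COc1ccc([C@H]2CC(=O)N(c3ccc(C)c(N)c3)C2)cc1OC1CCCC1` gives > 10000 nM in this assay, likewise a limit. Compound 3 `COc1ccc([C@H]2CC(=O)N(c3cc(N)cc(F)c3)C2)cc1OC1CCCC1` gives > 10000 nM, again only a limit. The steps among these three, a step that the two limits leave unreadable from compound 1 to compound 2, a step that the two limits leave unreadable from compound 1 to compound 3 and a step that the two limits leave unreadable from compound 2 to compound 3, therefore cannot be sized; all that is known is the limit of > 10000 nM in this assay, at which 3 of the 3 values shown sit.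

Compound 4 `COc1ccc([C@H]2CC(=O)N(c3cccc(NS(=O)(=O)c4c(F)cccc4F)c3)C2)cc1OC1CCCC1` differs from compound 1 as follows: ((2,6-difluorophenyl)sulfonyl)amino in place of hydrogen on an aromatic carbon. Among the measured compounds shown here, no measured step gives a readable size, so the series so far says only that compound 1 and its two relatives are tolerated up to the limit. For the measured compounds named here, the group that enters is larger than any change among compounds 1, 2 and 3, but no measured step bears directly on it. The expected step from compound 1 to compound 4 is therefore a number no higher from compound 1 to compound 4 (the limit leaves the size open), with no direction supported beyond the scatter. Compound 4 is expected to give 10000 nM, within 4000 nM to 25000 nM, most likely reported again only as a limit.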

Compound 4, half-maximal cytotoxic concentration: > 10000 nM
Compound 4 gave a limit, no number (the forecaster's own chance of this, stated with the estimate: 70%); the middle value sits exactly at the limit.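

The step from compound 1 to compound 4 cannot be read, since both values are limits and not numbers: the limit of > 10000 nM in this assay, at which 4 of the 4 values shown sit. The compounds shown leave open how much of any of them is tolerated, and whether the ((2,6-difluorophenyl)sulfonyl)amino group changes that amount at all.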